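Swapping the aryl group on the piperazine of compound 2

The source may report more compounds than this note shows. Statements on the series, on what has been measured and on what is new or still open speak of the compounds shown alone.

Measured compounds and values:
- compound 1 `CCCc1nc(-c2ccccc2)c(CNCCCN2CCN(c3cccc(OC)c3)CC2)o1`: 36.4%
- compound 2 `CCCc1nc(-c2ccccc2)c(CNCCN2CCN(c3ccc(C)cc3)CC2)o1`: 48.1%
- compound 3 `CCCc1nc(-c2ccccc2)c(CNCCCN2CCN(c3cccc(C)c3C)CC2)o1`: 55.2%

In an assay on HEK293 cells for inhibition of Voltage-dependent T-type calcium channel subunit alpha-1G (Homo sapiens), read by fluorescence, tested at 10 uM (on this read-out higher numbers stand for more inhibition at the one concentration tested (going by the name of the read-out) and lower numbers for less inhibition), compound 2 gives 48.1% and stands second highest of the three numbers. Compound 3 sits above it, but the gap is within the usual scatter of this kind of measurement, so the two cannot be ranked. Compound 1 lies below compound 2 by more than the scatter.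

Compound 4 `CCCc1nc(-c2ccccc2)c(CNCCN2CCN(c3cccc(F)c3)CC2)o1` has not yet been measured. It differs from compound 2 in one place: 3-fluorophenyl in place of 4-methylphenyl on an amine nitrogen in a ring. For the measured compounds named here, the only measured step that bears on this kind of change is a number 18.8 percentage points higher from compound 1 to compound 3 (beyond the scatter), which also replaces the group on the amine nitrogen in the ring, but with different groups than the ones exchanged here. Going by the values given here, no measured pair shows 3-fluorophenyl against 4-methylphenyl directly, so the direction is not settled.

Given the modest size of that one related step and the lack of a direct comparison, a change within the scatter is expected for compound 4, printed as a number 5.1 percentage points lower from compound 2 to compound 4 (within the scatter). Compound 4 is therefore estimated at 43%, with a range from 24% to 62%.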

Compound 4, a percentage reported as inhibition, at one concentration (the size of the read-out at that concentration, not a potency): 62.3%
For compound 4 the middle estimate is 19.3 percentage points below the measured one; the measured number lies above the stated range.
By their numbers in this assay, from the lowest: compound 1; then compounds 2, 3 and 4 (each within the scatter of the next, the first and the last beyond it).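

In this assay, the group on the amine nitrogen in the ring now has a direct comparison: 3-fluorophenyl in place of 4-methylphenyl gives a number 14.2 percentage points higher from compound 2 to compound 4 (beyond the scatter). For the compounds shown here, the only earlier step at this position came from compounds with a different chain linking this ring to the core, so the result shows that the aryl group can also move the read-out beyond the scatter when that chain is the one found in compound 2 and compound 4. The swap also leaves much of what is counted unchanged, since both groups have the same number of heavy atoms, one carbon-only aromatic ring, no hydrogen-bond donors or acceptors and no net charge, yet the number still shifts, and nothing measured here explains that shift.

The two groups differ both in the substituent, fluorine against methyl, and in its place on the phenyl ring, so these compounds cannot show which of the two differences matters. Going by these compounds, how a plain phenyl group or a chlorophenyl group would read on this nitrogen also remains open, as does whether the same swap would give a similar step with the other linking chain.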